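Capping a hydroxy as methoxy on the aromatic ring

This account rests on a few compounds, and the source may have more. Where it says the series, first, only, none or still open, it means among the compounds named here.

In a functional assay on A549 cells (Homo sapiens) for antiproliferative activity, read by MTT assay, with a stated time of 72 h (on this read-out lower numbers stand for stronger inhibition and higher numbers for weaker inhibition), compound 1 (`Cc1nc(C)c(/C=C/C(=O)/C=C/c2ccc(O)cc2)nc1C`) gives 4010 nM and compound 2 (`COc1cc(/C=C/C(=O)/C=C/c2nc(C)c(C)nc2C)ccc1O`) gives 2190 nM while compound 3 (`COc1ccccc1/C=C/C(=O)/C=C/c1nc(C)c(C)nc1C`) gives 3200 nM so compound 2 sits within the scatter of both others. Compound 4 (`COc1ccc(/C=C/C(=O)/C=C/c2nc(C)c(C)nc2C)cc1OC`) differs from compound 2 by methyl in place of hydrogen on an oxygen on an aromatic ring with methyl in place of hydrogen on an oxygen on an aromatic ring, turning hydroxy to methoxy. Within the data shown here, the one measured step that bears on this is a 1.8-fold lower number from compound 1 to compound 2 (0.26 log units; within the scatter) for methoxy in place of hydrogen on an aromatic carbon. It lies within the scatter and sits on a carbon rather than an oxygen, so it is only a loose guide. In this assay the expected size is therefore a 1.3-fold higher number from compound 2 to compound 4 (0.11 log units; within the scatter) and thus none beyond the scatter. For compound 4 the estimated value is 2800 nM with an expected range from 1200 nM to 6500 nM on this read-out.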

Compound 4, half-maximal inhibitory concentration: 3790 nM
The estimate for compound 4 lay 1.4-fold (0.13 log units) below the measured number; the measured number falls inside the stated range.
By their numbers in this assay, from the lowest: compounds 2, 3, 4 and 1 (each within the scatter of the next).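

Among these compounds, this is the first step here taken on the oxygen itself rather than on an aromatic carbon: in this assay putting methyl in place of hydrogen gives a 1.7-fold higher number from compound 2 to compound 4 (0.24 log units; within the scatter) and leaves hydroxy and methoxy at this place indistinguishable. The hydrogen of the hydroxy is therefore not shown to be needed for this read-out. No measurement at hand gives a reason for this result.
Still open, on these data alone, is whether a larger group on this oxygen, such as an ethyl or a longer chain, would stay within the scatter. As far as these compounds go, an amine at this place is equally open.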